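The source may report more compounds than this note shows. Statements on the series, on what has been measured and on what is new or still open speak of the compounds shown alone.

Measured compounds in an assay for inhibition of serine/threonine-protein kinase PLK2 (Homo sapiens), read by FRET and Z'-LYTE, with a stated time of 1 h; a higher number here means a weaker inhibitor, a lower number a stronger inhibitor:
compound 1 `CCC1C(=O)N(C)c2cnc(-n3ccc4cc(C(=O)NC(C)C)ccc43)nc2N1c1ccn(C)n1`: 125 nM
compound 2 `CCC1C(=O)N(C)c2cnc(-n3ccc4cc(F)ccc43)nc2N1c1ccn(C)n1`: 1500 nM
compound 3 `CCCNC(=O)c1ccc2c(ccn2-c2ncc3c(n2)N(c2ccn(C)n2)C(CC)C(=O)N3C)c1`: 207 nM

Compound 3 stands second highest of the three numbers. Its nearest neighbour is compound 1, the gap being a 1.7-fold higher number from compound 1 to compound 3 (0.22 log units; within the scatter); its furthest is compound 2, with a 7.2-fold lower number from compound 2 to compound 3 (0.86 log units; beyond the scatter). The large separation of compound 2 comes from the amide group itself, as a 12-fold higher number from compound 1 to compound 2 (1.08 log units; beyond the scatter) shows.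

Compound 4 `CCC1C(=O)N(C)c2cnc(-n3ccc4cc(C(=O)NCC(C)C)ccc43)nc2N1c1ccn(C)n1` differs from compound 3 by methyl in place of hydrogen on a saturated chain carbon bound to two saturated chain carbons. Going by the values given here, the only measured step that bears on this is the exchange of alkyls on the amide nitrogen, a 1.7-fold higher number from compound 1 to compound 3 (0.22 log units; within the scatter), which lay within the scatter. A step of no more than that size is therefore expected in this assay from compound 3 to compound 4, a 1.2-fold lower number from compound 3 to compound 4 (0.06 log units; within the scatter). Compound 4 is estimated at 180 nM, with a range of 80 nM to 450 nM.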

Compound 4, half-maximal inhibitory concentration: 159 nM
Beside the measured number, compound 4's estimate is 1.1-fold (0.05 log units) above it; the range from low to high includes it.
By their numbers in this assay, from the lowest: compounds 1, 4 and 3 (each within the scatter of the next); then compound 2.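

In this assay, methyl in place of hydrogen on a saturated chain carbon bound to two saturated chain carbons leaves the number within the scatter (a 1.3-fold lower number from compound 3 to compound 4 (0.11 log units; within the scatter)), and isobutyl in place of isopropyl on the amide nitrogen does the same (a 1.3-fold higher number from compound 1 to compound 4 (0.10 log units; within the scatter)). Compounds 1, 3 and 4 therefore cannot be told apart, and the gain of the amide over fluoro holds with the isobutyl chain too (a 9.4-fold lower number from compound 2 to compound 4 (0.97 log units; beyond the scatter)). No measured evidence explains this tolerance of the alkyl chain. From the compounds shown here alone, whether an amine, a carboxylic acid or a longer chain at this position would keep the same level remains open.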